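The source may hold more compounds than are shown below. What is called first, only, known or untested is meant among the compounds shown, and "the series" means these compounds.

Measured so far:
compound 1 `N#CNC(=N)NCCCCCn1nc(-c2ccccc2)ccc1=O` — a functional assay on the whole organism (stomach) with Rattus norvegicus as the target; a lower number here means that less compound is needed, a higher number that more compound is needed for the effect: > 100 mg/kg
compound 2 `CC/N=C(/NC#N)NCCCCCCn1nc(-c2ccccc2)ccc1=O` — this assay: > 100 mg/kg

Compound 2 stands only at a limit of this assay, not a number. Compound 1 likewise gives a limit. Both values shown sit at the limit of > 100 mg/kg in this assay, at which 2 of the 2 values shown sit. The step that the two limits leave unreadable from compound 1 to compound 2 is therefore unreadable in size.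

Compound 3 `CN(C)/C(=N/CCCCCn1nc(-c2ccccc2)ccc1=O)NC#N` differs from compound 2 by a group of 8 heavy atoms (4 carbon, 4 nitrogen; no ring) in place of a group of 9 heavy atoms (5 carbon, 4 nitrogen; no ring), on a saturated chain carbon, five bonds along the chain from an aromatic nitrogen. Among the compounds with values here, no measured step gives a readable size for a change at this place, so no direction beyond the scatter is expected in this assay. Compound 3 is expected to give a limit again, estimated at 150 mg/kg, range 40 mg/kg to 600 mg/kg. The expected step that the limit leaves unreadable from compound 2 to compound 3 is within the scatter.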

Compound 3, dose for half-maximal effect: 81.5 mg/kg
Estimate against measurement, compound 3: 1.8-fold (0.26 log units) above; the measured number falls inside the stated range.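

In this assay, within the data shown here, compound 3 gives 81.5 mg/kg as the first number of the series rather than a limit, so this position, five bonds along the chain from an aromatic nitrogen, can return a measurable value with the group of 8 heavy atoms. The steps read an at least 1.2-fold lower number from compound 2 to compound 3 (0.08 log units; that floor lies within the scatter) and an at least 1.2-fold lower number from compound 1 to compound 3 (0.08 log units; that floor lies within the scatter) as floors only, so no real difference from either compound is established. Compound 1 and compound 2 remain limits, not numbers: the limit of > 100 mg/kg in this assay, at which 2 of the 3 values shown sit.

On these data alone, the true size of both steps stays open. Also open, as far as these compounds go, is whether an amine or a carboxylic acid at this place, or a longer chain, would give a lower number.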